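The compounds below may be only part of what the source reports. "The series", "measured", "known", "first", "only" and "open" are said of these compounds alone.

Measured compounds:
- compound 1 `Fc1ccc2ncc(-c3nn[nH]n3)cc2c1` gives 50 mg/kg in a functional assay on the whole organism (strain Sprague-Dawley) for inhibition, with Rattus norvegicus as the target; a higher number here means that more compound is needed for the effect, a lower number that less compound is needed
- compound 2 `c1cc2ncc(-c3nn[nH]n3)cc2cc1OC1CCCCC1` gives 10 mg/kg in this assay
- compound 3 `FC(F)(F)c1cccc2cc(-c3nn[nH]n3)cnc12` gives 25 mg/kg in this assay

Compound 3 holds the second highest of the three numbers. Its nearest neighbour is compound 1, whose number is higher but within the scatter, so the two cannot be ordered. Compound 2 sits further off, with a number lower than that of compound 3 by a margin beyond the scatter.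

Compound 4 `c1ccc2ncc(-c3nn[nH]n3)cc2c1` has not been measured. It differs from compound 3 by hydrogen in place of trifluoromethyl on an aromatic carbon.

Among the compounds with values here, only one measured step is available, a 5.0-fold lower number from compound 1 to compound 2 (0.70 log units; beyond the scatter), and it concerns a different substituent at that carbon, so it bears on the present change only loosely. Compounds 1 and 3, which carry fluoro and trifluoromethyl there, lie within the scatter of each other, which suggests that small groups at this position move the number little. The expectation for compound 4 is therefore a step of a 1.4-fold higher number from compound 3 to compound 4 (0.15 log units; within the scatter), no larger than the scatter. Compound 4 is estimated at 35 mg/kg, with a range from 15 mg/kg to 100 mg/kg.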

Compound 4, minimum effective dose: 25 mg/kg
The estimate for compound 4 lay 1.4-fold (0.15 log units) above the measured number; low and high end bracket the measured number.
By their numbers in this assay, from the lowest: compound 2; then compounds 3, 4 and 1 (each within the scatter of the next).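

With the unsubstituted compound 4 as a reference in this assay, trifluoromethyl on this aromatic carbon brings no readable gain over hydrogen: no change at the digits printed from compound 3 to compound 4 (within the scatter) stays within the scatter, and the fluoro of compound 1 likewise gives a 2.0-fold lower number from compound 1 to compound 4 (0.30 log units; within the scatter) on its removal. Of the three substituents, only cyclohexyloxy stands apart from the bare core, with a 2.5-fold higher number from compound 2 to compound 4 (0.40 log units; beyond the scatter) beyond the scatter, so the lower number goes with that group alone among the compounds shown. No measurement at hand offers a reason for these numbers.

Open, from the compounds shown here alone, is whether the lower number of compound 2 follows the ether oxygen or the cyclohexyl ring, which a methoxy group or a longer alkoxy chain could separate. Also open, going by these compounds, is how cyclohexyloxy, an amine or a carboxylic acid would read on the carbon that carries trifluoromethyl in compound 3.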